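The source may report more compounds than this note shows. Statements on the series, on what has been measured and on what is new or still open speak of the compounds shown alone.

Measured in a functional assay on HT-29 cells (Homo sapiens) for inhibition, with a stated time of 72 h; a lower number here means a stronger inhibitor, a higher number a weaker inhibitor:
- Compound 1 `COc1ccc(S(=O)(=O)N2CCc3cccc(-c4ccc(N)cc4)c32)cc1`: 301 nM
- Compound 2 `COc1ccc(S(=O)(=O)N2CCc3cccc(-c4ccc(F)nc4)c32)cc1`: 109 nM
- Compound 3 `COc1ccc(S(=O)(=O)N2CCc3cccc(-c4ccncc4)c32)cc1`: 87.5 nM

Compound 3 sits at the low end of this short series. The nearest comparison shows a 1.2-fold lower number from compound 2 to compound 3 (0.10 log units; within the scatter), which lies within the scatter, while the furthest shows a 3.4-fold lower number from compound 1 to compound 3 (0.54 log units; beyond the scatter), which lies beyond it.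

The next structure, compound 4 `COc1ccc(S(=O)(=O)N2CCc3cccc(-c4ccccc4)c32)cc1`, has not yet been measured. It differs from compound 3 as follows: phenyl in place of pyridin-4-yl on an aromatic carbon. This places phenyl in place of pyridin-4-yl on an aromatic carbon.

Among the compounds with values here, no measured step makes this exact exchange. The closest evidence comes from the two steps away from the 4-aminophenyl group, a 2.8-fold lower number from compound 1 to compound 2 (0.44 log units; beyond the scatter) and a 3.4-fold lower number from compound 1 to compound 3 (0.54 log units; beyond the scatter), both modest. However, compound 1 carries an amino group that compound 4 lacks, so these steps can only be a partial guide. A small step toward a higher number in this assay is therefore expected, possibly no larger than the scatter.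

For compound 4 the expected step is a 1.8-fold higher number from compound 3 to compound 4 (0.26 log units; within the scatter). The estimated value for compound 4 is 160 nM, with an expected range of 60 nM to 420 nM.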

Compound 4, half-maximal inhibitory concentration: 96.5 nM
Compound 4: middle estimate off by 1.7-fold (0.22 log units), on the high side; the measured number falls inside the stated range.
By their numbers in this assay, from the lowest: compounds 3, 4 and 2 (each within the scatter of the next); then compound 1.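

In this assay phenyl in place of pyridin-4-yl gives a 1.1-fold higher number from compound 3 to compound 4 (0.04 log units; within the scatter) and phenyl in place of 6-fluoropyridin-3-yl gives a 1.1-fold lower number from compound 2 to compound 4 (0.05 log units; within the scatter) so at this position a ring of carbon only serves as well as either nitrogen-bearing ring, and no ring nitrogen is required to reach this level. Hydrogen in place of amino gives a 3.1-fold lower number from compound 1 to compound 4 (0.49 log units; beyond the scatter) and this step lies beyond the scatter, so the higher number of compound 1 goes with the amino group and not with the phenyl ring that carries it. Nothing available explains why these exchanges behave as they do.

Whether the amino group is a special case stays open, since a hydroxyl, a methoxy or a carboxylic acid on the phenyl ring does not appear among these compounds. Equally open, going by these compounds, is how a saturated ring such as piperidine or morpholine would fare on this aromatic carbon.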